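The compounds below may be only part of what the source reports. "The series", "measured", "known", "first", "only" and "open" are said of these compounds alone.

Measured in a functional assay on KB cells (Homo sapiens) for inhibition, read by MTT assay, with a stated time of 24 h, tested at 100 ug/mL; a higher number here means more inhibition of growth at the concentration tested, a lower number less inhibition of growth:

Compound 1 `O=C(CCCCC1CCSS1)Nc1ccccn1`: 25.1%
Compound 2 `O=C(CCCCC1CCSS1)Nc1ccc(Cl)cn1`: 74.5%
Compound 3 `O=C(CCCCC(S)CCS)Nc1ccccn1`: 18.5%

In this assay compound 3 gives 18.5%. That number lies within the scatter of compound 1 and far from compound 2, whose own number is well beyond the scatter of it. Compound 4 `O=C(CCCCC(S)CCS)Nc1ccc(Cl)cn1` differs from compound 3 in one place: chloro in place of hydrogen on an aromatic carbon. This is chloro in place of hydrogen on an aromatic carbon, two atoms from the ring nitrogen and para to a large group.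

Going by the values given here, two measured steps bear on this change. The same replacement has been measured once, on the ring-bearing compound 1, as a number 49.4 percentage points higher from compound 1 to compound 2 (beyond the scatter), a large step beyond the scatter. The other step, a number 6.6 percentage points lower from compound 1 to compound 3 (within the scatter), stays within the scatter, so compound 1 and compound 3 offer closely similar starting points. Whether the chloro step carries over to the open chain has not been measured, and it rests on a single pair. A large upward step is still expected, perhaps somewhat smaller than the measured one. Expected in this assay is therefore a number 43.5 percentage points higher from compound 3 to compound 4 (beyond the scatter). For compound 4 the estimated value is 62%, within an expected range of 38% to 82%.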

Compound 4, percent growth inhibition at one concentration: 76.6%
Compound 4: the middle estimate sits 14.6 percentage points below what was measured; the range from low to high includes it.
By their numbers in this assay, from the lowest: compounds 3 and 1 (each within the scatter of the next); then compounds 2 and 4 (each within the scatter of the next).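

In this assay, the replacement of hydrogen by chloro on this aromatic carbon, two atoms from the ring nitrogen and para to a large group, also holds on the open chain, giving a number 58.1 percentage points higher from compound 3 to compound 4 (beyond the scatter). The change therefore no longer rests on a single pair, and its size carries over from one core to the other: the same change on two cores in this assay, a number 49.4 percentage points higher (beyond the scatter) from compound 1 to compound 2 and a number 58.1 percentage points higher (beyond the scatter) from compound 3 to compound 4, 8.7 percentage points apart, within the scatter of two such steps

Opening the five-membered non-aromatic ring also remains within the scatter when the chloro is present, giving a number 2.1 percentage points higher from compound 2 to compound 4 (within the scatter), so the earlier result for this exchange without chloro is repeated: the same change on two cores in this assay, a number 6.6 percentage points lower (within the scatter) from compound 1 to compound 3 and a number 2.1 percentage points higher (within the scatter) from compound 2 to compound 4, 8.7 percentage points apart, within the scatter of two such steps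

The compounds shown do not tell whether fluoro, methyl or an amine on this same aromatic carbon would give a step of similar size. They also leave open how a longer chain between the carbonyl and the sulfur-bearing end would behave, and how compound 2 and compound 4 would compare across a range of concentrations rather than at the one tested.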